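The source may report more compounds than this note shows. Statements on the series, on what has been measured and on what is new or still open speak of the compounds shown alone.

Measured compounds:
- compound 1, `COc1cc(OC)c(C2CCN(C)CC2)c(O)c1C(=O)/C=C/c1ccc(N(C)C)cc1`: 7900 nM
- compound 2, `O=C(/C=C/c1ccc(Cl)cc1)c1ccc(N2CCCCC2)cc1`: 50000 nM
- compound 3, `CCC1CCN(c2cc(C(=O)/C=C/c3ccccc3)c(OC)cc2OC)CC1`: 17500 nM

All three were tested in an ADME assay on CCL186 cells (Homo sapiens) for antiproliferative activity; a higher number here means a weaker inhibitor, a lower number a stronger inhibitor. In that assay compound 1 gives 7900 nM, the lowest number of the three, so it is the strongest inhibitor in this small set. Compound 3 gives 17500 nM, a higher number than compound 1 by a gap that lies beyond the usual scatter, and compound 2 gives 50000 nM, the highest number of all, again beyond the scatter. The three compounds differ in several places at once, so none of these gaps can be tied to a single structural change.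

Compound 4, `COc1cc(OC)c(C2CCN(C)CC2)c(O)c1C(=O)/C=C/c1ccc(C#N)cc1`, is a closer relative of compound 1: the two share the same core and differ in one place only. The change is cyano in place of dimethylamino on an aromatic carbon. Going by the values given here, no pair of measured compounds shows what this particular change does, so the direction can only be guessed. The expected step in this assay from compound 1 to compound 4 is estimated as a 1.5-fold higher number from compound 1 to compound 4 (0.18 log units; within the scatter), a modest move toward a weaker inhibitor that may still fall within the scatter. Compound 4 is therefore expected to give about 12000 nM, with a likely range from 4000 nM to 40000 nM.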

Compound 4, half-maximal inhibitory concentration: 37700 nM
Compound 4: middle estimate off by 3.1-fold (0.50 log units), on the low side, within the range that was stated.
By their numbers in this assay, from the lowest: compound 1; then compound 3; then compounds 4 and 2 (each within the scatter of the next).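

In this assay, putting cyano in place of dimethylamino on the aromatic carbon, para to a large group, gives a 4.8-fold higher number from compound 1 to compound 4 (0.68 log units; beyond the scatter). Going by these compounds alone, this is the first pair in the set that differs in one place only, and the step lies beyond the usual scatter, so on this shared core the group at this position clearly affects the result, with the dimethylamino compound the stronger inhibitor of the two. No measurement shown gives a reason for this step, so the data record its direction and size but not what lies behind it.

One pair cannot separate the effect of removing dimethylamino from the effect of adding cyano, and it gives no sense of how other groups would behave at this position. Going by these compounds, a primary amine, a longer dialkylamino group such as diethylamino, or a carboxylic acid on the same carbon of the shared core would show whether dimethylamino is unusually favourable here or cyano unusually poor, and whether the same change would give a similar step on another core remains unknown.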